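The compounds below may be only part of what the source reports. "The series", "measured", "known", "first", "only" and "open" are said of these compounds alone.

Measured so far:
Compound 1 `CNC(=O)c1cc(C(=O)N[C@H]2CC[C@H](O)CC2)n([C@@H](C)c2cccc(C(F)(F)F)c2)n1`: 7 ug/mL
Compound 2 `CC[C@@H](c1ccccc1)n1nc(C(=O)NC)cc1C(=O)N[C@H]1CC[C@H](O)CC1`: 138 ug/mL

In a physicochemical assay for solubility, measured as kinetic solubility (on this read-out lower numbers stand for lower solubility and higher numbers for higher solubility), compound 2 holds the higher of the two numbers, and the gap to compound 1 lies well beyond the scatter. Compound 3 `CNC(=O)c1cc(C(=O)N[C@H]2CC[C@H](O)CC2)n([C@@H](C)c2cccc(C)c2)n1` has not yet been measured. It carries 1-(3-methylphenyl)ethyl in place of 1-phenylpropyl on an aromatic nitrogen. Among the measured compounds shown here, no measured pair isolates this change, so the guide is weak. For the measured compounds named here, the new group looks more like the one on compound 1, which gives 7 ug/mL. A fall beyond the scatter is therefore expected, an estimated 3.9-fold lower number from compound 2 to compound 3 (0.60 log units; beyond the scatter). For compound 3 the expected value is 35 ug/mL, with an estimated range of 10 ug/mL to 110 ug/mL.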

Compound 3, solubility: >= 180 ug/mL
Compound 3 was reported as a limit (the forecaster's own chance of this, stated with the estimate: 3%); middle value at least 5.1-fold (0.71 log units) away from the limit.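

In this assay the value of compound 3, >= 180 ug/mL, is a limit of the assay and not a number: the limit of >= 180 ug/mL in this assay, at which 1 of the 3 values shown sits. Methyl in place of trifluoromethyl on an aromatic carbon gives an at least 25-fold higher number from compound 1 to compound 3 (1.41 log units; beyond the scatter), the first comparison here that isolates this one place, and the step is large. Putting 1-(3-methylphenyl)ethyl in place of 1-phenylpropyl on an aromatic nitrogen gives an at least 1.3-fold higher number from compound 2 to compound 3 (0.11 log units; that floor lies within the scatter), and that floor lies within the scatter, so this step alone shows no real gain.

From the compounds shown here alone, how far compound 3 truly lies from compound 2 stays open. So does whether chlorine, methoxy or an amine on that aromatic carbon would track with methyl or with trifluoromethyl.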